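Moving the Methoxy Group on the Amide Aryl Ring

A few compounds are considered here, and "the series" means these few. Any claim that something is new, unique, unknown or untested is made for them only; others in the source may bear on it.

Compound 1 `O=C(NN1CCOCC1)c1c(O)c2cccnc2n(-c2ccccc2)c1=O`: -26.2%
Compound 2 `COc1cccc(NC(=O)c2c(O)c3cccnc3n(-c3ccccc3)c2=O)c1`: 20.7%

In a functional assay on the whole organism for inhibition, with Rattus norvegicus as the target, read by cytopathic effect and paw edema, at a dose of 100 mg/kg by the oral route (on this read-out lower numbers stand for less inhibition and higher numbers for more inhibition at the one dose given (going by the name of the read-out)), compound 2 gives 20.7%, the higher of the two numbers, while compound 1 gives -26.2%. Within the data shown here, the only known step, a number 46.9 percentage points higher from compound 1 to compound 2 (beyond the scatter), exchanged the whole group on the amide nitrogen rather than shifting a methoxy group within it. Compound 3 `COc1ccccc1NC(=O)c1c(O)c2cccnc2n(-c2ccccc2)c1=O` differs from compound 2 by 2-methoxyphenyl in place of 3-methoxyphenyl on an amide-type nitrogen. Among the measured compounds shown here, no measured step tests such a shift, so nothing beyond the scatter is expected in this assay. The estimate for compound 3 is 15%, with a range from -15% to 42%. This expectation amounts to a step of a number 5.7 percentage points lower from compound 2 to compound 3 (within the scatter).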

Compound 3, a percentage reported as inhibition, in the whole organism at one dose (the size of the read-out at that dose, not a potency): -10.1%
For compound 3 the middle estimate is 25.1 percentage points above the measured one, within the range that was stated.
By their numbers in this assay, from the lowest: compound 1; then compound 3; then compound 2.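

In this assay, changing 3-methoxyphenyl to 2-methoxyphenyl on the amide-type nitrogen gives a number 30.8 percentage points lower from compound 2 to compound 3 (beyond the scatter), so the arrangement of the same atoms in this group can matter, not only the type of group present. The aryl amide with 2-methoxyphenyl still compares well with morpholin-4-yl, at a number 16.1 percentage points higher from compound 1 to compound 3 (beyond the scatter), so part of the difference between those groups remains after the shift. Nothing available explains why this shift changes the read-out. Still open, on these data alone, is whether a hydroxy group or a dimethylamino group in place of the methoxy group would match compound 2.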